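The compounds below may be only part of what the source reports. "The series", "measured", "known", "first", "only" and "open" are said of these compounds alone.

Measured so far:
compound 1 `FC(F)(F)Oc1ccc(-c2ccc(-c3ccc(-c4nc5ccccc5[nH]4)cc3)cc2)cc1`: 100000 nM
compound 2 `Oc1cccc2[nH]c(-c3ccc(-c4ccc(-c5ccc(F)cc5)cc4)cc3)nc12`: 15300 nM

In a functional assay on PC-3 cells (Homo sapiens) for inhibition, read by sulforhodamine B assay (on this read-out higher numbers stand for weaker inhibition of growth and lower numbers for stronger inhibition of growth), compound 2 holds the lower of the two numbers, 15300 nM, and the gap to compound 1 lies beyond the scatter. Compound 3 `Oc1cccc2[nH]c(-c3ccc(-c4ccc(-c5ccc(OC(F)(F)F)cc5)cc4)cc3)nc12` carries trifluoromethoxy in place of the fluoro of compound 2, on an aromatic carbon, para to a large group: trifluoromethoxy in place of fluoro on an aromatic carbon. Within the data shown here, no measured step between compounds differing in one place is available, so the expectation rests on thin evidence. Compound 1 also bears trifluoromethoxy but differs from compound 2 in more than this group, and compound 1 gives 100000 nM. A moderate move toward weaker inhibition of growth in this assay is expected, though a result within the scatter remains possible. The expected change is a 1.7-fold higher number from compound 2 to compound 3 (0.23 log units; within the scatter). For compound 3 the estimated value is 26000 nM, with an expected range of 9000 nM to 80000 nM.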

Compound 3, concentration for 50% growth inhibition: 7410 nM
Estimate against measurement, compound 3: 3.5-fold (0.55 log units) above; measured number below the stated range.
By their numbers in this assay, from the lowest: compound 3; then compound 2; then compound 1.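

In this assay, among these compounds, trifluoromethoxy in place of fluoro on an aromatic carbon, para to a large group, gives a 2.1-fold lower number from compound 2 to compound 3 (0.31 log units; beyond the scatter) and so gives the first one-place reading at this position: the larger group, with 5 heavy atoms against 1, comes with stronger inhibition of growth, not weaker. A second one-place reading, with trifluoromethoxy held constant, is hydroxy in place of hydrogen on an aromatic carbon, which gives a 13-fold lower number from compound 1 to compound 3 (1.13 log units; beyond the scatter) and counts as a large step, while the change at the fluoro position counts as modest. Among the compounds shown here, both groups thus have a matched comparison for the first time.

From the compounds shown here alone, how an amine or a carboxylic acid would read at the para position remains open, as does whether the hydroxy step would carry over with fluoro in place of trifluoromethoxy. No measurement at hand bears on the reason for either step.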